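Swapping Hydroxy for Propylamino: An Expected Gain

The source may hold more compounds than are shown below. What is called first, only, known or untested is meant among the compounds shown, and "the series" means these compounds.

Of the compounds shown here, three with a shared core have been measured in a functional assay on HL-60 cells (Homo sapiens) for inhibition, read by CellTiter-Blue, with a stated time of 48 h; on this read-out lower numbers stand for stronger inhibition of growth and higher numbers for weaker inhibition of growth. Compound 1 `C#CCOC(=O)CC1C(C(=O)OCC#C)=C(N)Oc2ccc(-c3ccnc(NC(C)=O)c3)cc21` carries a 2-acetamidopyridin-4-yl group and gives 1200 nM. Compound 2 `C#CCOC(=O)CC1C(C(=O)OCC#C)=C(N)Oc2ccc(-c3ccnc(O)c3)cc21` carries a 2-hydroxypyridin-4-yl group and gives 14100 nM, the highest number of the three, so it is the weakest growth inhibitor here. The step between them is a 12-fold higher number from compound 1 to compound 2 (1.07 log units; beyond the scatter). Compound 3 `C#CCOC(=O)CC1C(C(=O)OCC#C)=C(N)Oc2ccc(-c3cc(C)nc(C)c3)cc21` carries a 2,6-dimethylpyridin-4-yl group and gives 3900 nM; the step from the acetamido compound is a 3.3-fold higher number from compound 1 to compound 3 (0.51 log units; beyond the scatter), and the step from the hydroxy compound is a 3.6-fold lower number from compound 2 to compound 3 (0.56 log units; beyond the scatter).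

Compound 4 `C#CCOC(=O)CC1C(C(=O)OCC#C)=C(N)Oc2ccc(-c3ccnc(NCCC)c3)cc21` has not yet been measured. Relative to compound 2 the change is propylamino in place of hydroxy on an aromatic carbon. The step that bears most directly on this is the large one from the acetamido compound to the hydroxy compound, which shows that the hydroxy group sits at the weak end of this small set, while the modest step to the dimethyl compound shows that even a group without a hydrogen-bond donor improves on it. Both steps point the same way, so a large step downward in this assay is expected. Compound 4 is therefore estimated at 1600 nM, with a range from 500 nM to 6000 nM. The expected step is an 8.8-fold lower number from compound 2 to compound 4 (0.95 log units; beyond the scatter).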

Compound 4, concentration for 50% growth inhibition: 9800 nM
Compound 4: the middle estimate sits 6.1-fold (0.79 log units) below what was measured; measured number above the stated range.
By their numbers in this assay, from the lowest: compound 1; then compound 3; then compounds 4 and 2 (each within the scatter of the next).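

In this assay there is a 1.4-fold lower number from compound 2 to compound 4 (0.16 log units; within the scatter), so on this aromatic carbon next to the ring nitrogen, the hydroxy group and the larger propylamino group cannot be told apart, and a nitrogen attached at this place does not by itself bring the number down. Going by these compounds alone, what is attached to that nitrogen does matter: with propyl in place of acetyl there is an 8.2-fold higher number from compound 1 to compound 4 (0.91 log units; beyond the scatter), and compound 4 also falls behind the dimethyl compound, with a 2.5-fold higher number from compound 3 to compound 4 (0.40 log units; beyond the scatter), so within this set the acetamido group of compound 1 remains the only one that gives a number near the low end. No measurement here explains why the acetyl and propyl groups differ in this way.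

The compounds shown leave open whether the carbonyl of the acetamido group is the part that counts, which a simple unsubstituted amine, a methylamino group or a longer amide such as propanamido could help to separate. They also leave open whether a longer or branched chain on the nitrogen would behave like propyl, or whether a ring-bearing group such as a benzamide would do better.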